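The compounds below may be only part of what the source reports. "The series", "measured", "known", "first", "only" and "open" are said of these compounds alone.

Measured so far in a functional assay on U-937 cells (Homo sapiens) for cytotoxicity; a higher number here means that more compound is tolerated, a lower number that less compound is tolerated: compound 1 `Cc1ccc(OC(CCn2ccnc2)c2ccccc2)cc1` gives 141000 nM; compound 2 `Cc1ccc(C(CCn2ccnc2)Oc2ccc(Cl)cc2Cl)cc1` gives 40000 nM; compound 3 `Fc1ccc(OC(CCn2ccnc2)c2ccccc2)c(F)c1` gives 219000 nM.

Compound 1 stands second highest of the three numbers. Its value and that of compound 3 lie within the usual scatter of each other, so no order between them can be read. Compound 2 gives the lowest number, and its gap to compound 1 is beyond the scatter.

Compound 4 `FC(F)(F)c1ccc(OC(CCn2ccnc2)c2ccccc2)cc1` differs from compound 1 by trifluoromethyl in place of methyl on an aromatic carbon. For the measured compounds named here, no measured pair shows this change, so the size of the step has to be guessed. The whole set sits in a narrow band, and the expectation is for no step beyond the scatter, in either direction. For compound 4 the estimated value in this assay is 100000 nM, with a range from 40000 nM to 250000 nM. The expected step is then a 1.4-fold lower number from compound 1 to compound 4 (0.15 log units; within the scatter), which is small against the scatter.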

Compound 4, half-maximal cytotoxic concentration: 86000 nM
Estimate against measurement, compound 4: 1.2-fold (0.07 log units) above; the measured number falls inside the stated range.
By their numbers in this assay, from the lowest: compound 2; then compounds 4, 1 and 3 (each within the scatter of the next, the first and the last beyond it).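

In this assay the exchange of methyl for trifluoromethyl on an aromatic carbon, para to a large group, gives a 1.6-fold lower number from compound 1 to compound 4 (0.21 log units; within the scatter) as the first step read at this position. This position therefore tolerates the larger trifluoromethyl group with no step beyond the scatter in this assay. No measurement on hand bears on why the step is this size. Open, as far as these compounds go, is whether an amine or a carboxylic acid at this position would give a step beyond the scatter, and whether trifluoromethyl gives a similar step on other members.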